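Acetyl to methoxycarbonyl: outlook for compound 3

The compounds below may be only part of what the source reports. "The series", "measured", "known", "first", "only" and "open" are said of these compounds alone.

Compound 2 `CC(=O)N1CCC[C@H](c2csc(-c3ccccc3NC(=O)c3ncc[nH]3)n2)C1` carries an acetyl on the amine nitrogen in the ring; in an ADME assay on microsomes from liver (Homo sapiens) (on this read-out lower numbers stand for lower hepatic extraction and higher numbers for higher hepatic extraction), compound 2 gives 0.78. Compound 1 `CCS(=O)(=O)N1CCC[C@H](c2csc(-c3ccccc3NC(=O)c3ncc[nH]3)n2)C1`, the ethylsulfonyl counterpart, gives 0.95 in this assay. Among the compounds with values here, compound 2 thus stands lowest of the two measured numbers, and the single measured step, a number 0.17 lower from compound 1 to compound 2 (beyond the scatter), is the only guide for the move from compound 2 to compound 3.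

Compound 3 `COC(=O)N1CCC[C@H](c2csc(-c3ccccc3NC(=O)c3ncc[nH]3)n2)C1` differs from compound 2 by methoxy in place of methyl on a carbonyl carbon. Within the data shown here, no measured pair shows how methoxy in place of methyl on this carbonyl carbon moves the number. The step from compound 1 to compound 2 concerns a different exchange; its modest size is the only scale at hand, and a step no larger than that is expected here. For compound 3 the expected step is a number 0.010 lower from compound 2 to compound 3 (within the scatter), that is, no change beyond the scatter. Compound 3 is therefore estimated at 0.77, with a range from 0.6 to 0.9.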

Compound 3, hepatic extraction ratio: 0.75
Beside the measured number, compound 3's estimate is 0.020 above it; measured number inside the range.
By their numbers in this assay, from the lowest: compounds 3 and 2 (each within the scatter of the next); then compound 1.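

Methoxy in place of methyl on this carbonyl carbon gives a number 0.030 lower from compound 2 to compound 3 (within the scatter) in this assay, so acetyl and methoxycarbonyl on the amine nitrogen in the ring cannot be told apart on this read-out. Methoxycarbonyl in place of ethylsulfonyl gives a number 0.20 lower from compound 1 to compound 3 (beyond the scatter), of modest size and in the same direction as a number 0.17 lower from compound 1 to compound 2 (beyond the scatter), so among these three compounds the gap lies between ethylsulfonyl and the two carbonyl groups, not between those two. No measurement at hand speaks to what lies behind this pattern.

Open, going by these compounds, is whether any other group on this carbonyl carbon, such as dimethylamino or a longer chain like ethoxy, would stand apart from compound 2 and compound 3. Also open, on these data alone, is whether the number of compound 1 goes with the sulfonyl or with its ethyl chain, a question that methylsulfonyl on the same nitrogen would address.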